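The source may hold more compounds than are shown below. What is called first, only, known or untested is meant among the compounds shown, and "the series" means these compounds.

The compounds here share one core and differ in the aromatic group carried on an aromatic nitrogen. In an ADME assay on the whole organism (strain Sprague-Dawley) for pharmacokinetics, with Rattus norvegicus as the target (a higher number here means faster removal of the compound, a lower number slower removal), compound 1 (`Nc1nc(Nc2ccc(N3CCN(C4CC5CCC4C5)CC3)cc2)nn1-c1nccc2ccccc12`) gives 52 mL/min/kg as its clearance. For compound 2 (`Nc1nc(Nc2ccc(N3CCN(C4CC5CCC4C5)CC3)cc2)nn1-c1ncnc2ccc(Cl)cc12`) the entry in this assay reads "not determined" (no result reported) and holds no number, so compound 2 has no place on this scale.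

Compound 3 (`Cc1csc2c(-n3nc(Nc4ccc(N5CCN(C6CC7CCC6C7)CC5)cc4)nc3N)nc(Cl)nc12`) differs from compound 2 in one place, on an aromatic nitrogen. The change is a group of 11 heavy atoms (7 carbon, 2 nitrogen, 1 sulfur, 1 chlorine; one five-membered aromatic ring with 1 hetero atom, one six-membered aromatic ring with 2 hetero atoms) in place of a group of 11 heavy atoms (8 carbon, 2 nitrogen, 1 chlorine; one six-membered aromatic ring of carbon only, one six-membered aromatic ring with 2 hetero atoms), on an aromatic nitrogen and it swaps the 6-chloroquinazolin-4-yl group for one in which a five-membered aromatic ring with 1 hetero atom replaces the six-membered aromatic ring of carbon only.

Among the compounds with values here, no measured step starts from compound 2, so the only anchor is compound 1 at 52 mL/min/kg in this assay terms. From that anchor, no step beyond the usual scatter is expected, and nothing measured here favours either direction. The clearance of compound 3 is estimated at 48 mL/min/kg in this assay with an expected range from 24 mL/min/kg to 90 mL/min/kg for the measurement.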

Compound 3, clearance: 11.5 mL/min/kg
Compound 3: the middle estimate sits 4.2-fold (0.62 log units) above what was measured; the measured number lies below the stated range.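

In this assay, the group on the aromatic nitrogen of the shared core now proves able to shift the read-out: replacing the two-ring group of compound 1 with the chlorine-bearing, sulfur-containing two-ring group of compound 3 gives a 4.5-fold lower number from compound 1 to compound 3 (0.66 log units; beyond the scatter), with the rest of the molecule unchanged. Within the data shown here, until this result there was only one clearance number, so nothing could be said about how clearance responds to a change at this position, while the step from compound 2 to compound 3 still cannot be read, as compound 2 holds no number. Nothing measured here accounts for the drop in clearance.

The two groups differ in several ways at once, including the five-membered aromatic ring with 1 hetero atom, the sulfur and the chlorine, so this single step cannot show which of these parts goes with the lower number. Also open, from the compounds shown here alone, is whether the lower clearance would hold if an amine or a methoxy group stood in place of the chlorine.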